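A side-chain swap on the shared core

The source may hold more compounds than are shown below. What is called first, only, known or untested is meant among the compounds shown, and "the series" means these compounds.

- compound 1 `COc1c(OCCCCN2CCCCC2)cc(O)c2c(=O)cc(-c3ccccc3)oc12`: 1150 nM
- compound 2 `COc1c(OCCCCN2CCCC2)cc(O)c2c(=O)cc(-c3ccccc3)oc12`: 1530 nM
- compound 3 `COc1c(OCCCN2CCN(C)CC2)cc(O)c2c(=O)cc(-c3ccccc3)oc12`: 9900 nM

In a functional assay on A549 cells (Homo sapiens) for cytotoxicity, read by MTT assay, with a stated time of 48 h (a lower number here means a stronger inhibitor, a higher number a weaker inhibitor), compound 3 has the highest number of the three. Compound 4 `CCN(CC)CCCCOc1cc(O)c2c(=O)cc(-c3ccccc3)oc2c1OC` differs from it by one change (diethylamino)methyl in place of 4-methylpiperazin-1-yl on a saturated chain carbon, three bonds along the chain from an oxygen on an aromatic ring: 3-(4-methylpiperazin-1-yl)propyl to 4-(diethylamino)butyl. Two measured steps resemble this change in reverse: an 8.6-fold higher number from compound 1 to compound 3 (0.93 log units; beyond the scatter) and a 6.5-fold higher number from compound 2 to compound 3 (0.81 log units; beyond the scatter). Within the data shown here, the step of a 1.3-fold higher number from compound 1 to compound 2 (0.12 log units; within the scatter) suggests that changing the group on the four-bond chain may matter little, although no measured compound lacks a ring there. A similar step towards a lower number is therefore expected in this assay. The expected step is a 5.5-fold lower number from compound 3 to compound 4 (0.74 log units; beyond the scatter). The estimate for compound 4 is 1800 nM, within a range of 800 nM to 4500 nM.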

Compound 4, half-maximal inhibitory concentration: 1000 nM
Compound 4: middle estimate off by 1.8-fold (0.26 log units), on the high side, and the stated range covers the measured number.
By their numbers in this assay, from the lowest: compounds 4, 1 and 2 (each within the scatter of the next); then compound 3.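

In this assay, an open-chain amine does as well as the ring amines on the four-bond chain: a 1.2-fold lower number from compound 1 to compound 4 (0.06 log units; within the scatter) and a 1.5-fold lower number from compound 2 to compound 4 (0.18 log units; within the scatter) both lie within the scatter. The large step of a 9.9-fold lower number from compound 3 to compound 4 (1.00 log units; beyond the scatter) sets compound 3 apart, but it changes both the ring and the chain length. No measurement here explains any of these results. The compounds shown leave open which of those two changes matters. A 4-(4-methylpiperazin-1-yl)butyl or 3-(diethylamino)propyl chain on the shared core would separate them.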